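The source may report more compounds than this note shows. Statements on the series, on what has been measured and on what is new or still open speak of the compounds shown alone.

Measured compounds:
- compound 1 `Cc1ccc(-n2cc(-c3ccccc3NS(=O)(=O)c3c[nH]c(=O)[nH]c3=O)nn2)cc1`: 32400 nM
- compound 2 `O=c1[nH]cc(S(=O)(=O)Nc2ccccc2-c2cn(-c3cccc(F)c3)nn2)c(=O)[nH]1`: "not toxic" (no number reported)
- compound 3 `O=c1[nH]cc(S(=O)(=O)Nc2ccc(-c3cn(-c4ccccc4)nn3)cc2)c(=O)[nH]1`: "not toxic" (no number reported)

All three were tested in an ADME assay on GES1 cells (Homo sapiens) for cytotoxicity, read by MTT assay, with a stated time of 24 h; on this read-out higher numbers stand for lower toxicity in this test and lower numbers for higher toxicity in this test. Compound 1 is the only one with a numerical result: in this assay compound 1 gives 32400 nM. For compound 2 the outcome is reported only in words, as "not toxic" (no number reported), with no number attached. Compound 3 stands in the same position: in this assay compound 3 is reported as "not toxic" (no number reported), again without a number, so it shares that wording with one other compound and cannot be ranked against compound 1 on a numerical scale.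

Compound 4 `O=c1[nH]cc(S(=O)(=O)Nc2ccc(-c3cn(-c4cccc(Cl)c4)nn3)cc2)c(=O)[nH]1` is not yet measured. It differs from compound 3 in one place: chloro in place of hydrogen on an aromatic carbon. The change is a single chlorine on the outer aromatic ring, meta to a large group; everything else, including the shared core, is kept.

For the measured compounds named here, no step between measured compounds is known, so there is no direct guide to what a chloro in place of hydrogen does here. The nearest point of reference is compound 3 itself, which showed no measurable toxicity. Given that, no shift beyond the usual scatter is expected in this assay, in either direction. Compound 4 is therefore expected to give about 50000 nM, within a range from 15000 nM to 200000 nM, and a wordy result without a number is quite possible.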

Compound 4, half-maximal cytotoxic concentration: 7570 nM
Compound 4: middle estimate off by 6.6-fold (0.82 log units), on the high side; measured number outside the range, below it.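

In this assay, for the compounds shown here, compound 3 is reported as "not toxic" (no number reported) with no number, while compound 4 gives 7570 nM as a number, so no step between these two compounds can be read. The compounds shown leave open how large the change from phenyl to 3-chlorophenyl is on this read-out. No measurement shown here bears on the reason for the result of compound 4.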